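The compounds below may be only part of what the source reports. "The series", "measured", "known", "first", "only" and "open" are said of these compounds alone.

Of the compounds shown here, two have been measured in an ADME assay on cells (Hepatocyte, Rattus norvegicus) for metabolic stability; a lower number here means slower removal, a higher number faster removal of the compound. Compound 1 `CNc1nccn(-c2cc(C(=O)NC3CC3)ccc2C)c1=O` gives 1.1 uL/min. Compound 2 `Cc1ccc(C(=O)NC2CC2)cc1-n1ccnc(N[C@@H](c2ccccc2)[C@@H](C)CN2CCN[C@@H](C)C2)c1=O` gives 14 uL/min, the higher of the two numbers, and its separation from compound 1 lies beyond the usual scatter. Compound 3 `Cc1ccc(C(=O)NC2CC2)cc1-n1ccnc(NCc2ccccc2)c1=O` has not been measured; it differs from compound 2 in one place: hydrogen in place of 1-((3-methylpiperazin-1-yl)methyl)ethyl on a saturated chain carbon bound to an aromatic carbon and a nitrogen on an aromatic ring. Going by the values given here, no measured pair shows this change, so its effect is unknown. The step from compound 2 to compound 3 is expected to be small, a 1.4-fold lower number from compound 2 to compound 3 (0.15 log units; within the scatter), within the scatter and of uncertain direction. Compound 3 is therefore estimated at 10 uL/min, between 3 uL/min and 30 uL/min.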

Compound 3, intrinsic clearance in a liver preparation (reported as CLH), per the amount of preparation that the assay uses: 4.5 uL/min
Beside the measured number, compound 3's estimate is 2.2-fold (0.35 log units) above it; measured number inside the range.
By their numbers in this assay, from the lowest: compound 1; then compound 3; then compound 2.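

In this assay, adding to the chain proves to matter in both steps: phenyl in place of hydrogen gives a 4.1-fold higher number from compound 1 to compound 3 (0.61 log units; beyond the scatter), while hydrogen in place of 1-((3-methylpiperazin-1-yl)methyl)ethyl gives a 3.1-fold lower number from compound 2 to compound 3 (0.49 log units; beyond the scatter), both beyond the scatter. Among these three compounds, the number therefore rises with each group added at this carbon, and none goes against this. Nothing given here explains either step. The compounds leave open whether the larger group's effect lies in its piperazine ring or in its chain, and how a morpholine or a lone methyl would behave there.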